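This account rests on a few compounds, and the source may have more. Where it says the series, first, only, none or still open, it means among the compounds named here.

Compound 1 `COc1ccc(CN(C(=O)CSc2nc3ccccc3s2)c2cc(OC)c(OC)c(OC)c2)cc1C` and compound 2 `COc1ccc(CN(C(=O)CSc2nc3cc(Br)ccc3s2)c2cc(OC)c(OC)c(OC)c2)cc1O` were both tested in a functional assay on MGC-803 cells (Homo sapiens) for antiproliferative activity, read by MTT assay, with a stated time of 48 h; a lower number here means a stronger inhibitor, a higher number a weaker inhibitor. Compound 1 gives 6360 nM in this assay, which is the higher of the two numbers recorded. Compound 2 differs from compound 1 at two places at once. In this assay compound 2 gives 372 nM, and the gap between the two lies well beyond the scatter of repeated measurements, though with two changes made together the two values alone cannot say which change carries the difference.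

Compound 3 `COc1cc(N(Cc2ccc(Br)cc2)C(=O)CSc2nc3ccccc3s2)cc(OC)c1OC` has not yet been measured in this assay. Relative to compound 1 it carries a single change: 4-bromophenyl in place of 4-methoxy-3-methylphenyl on a saturated chain carbon bound to an amide-type nitrogen. The shared core of compound 1 is kept unchanged. Among the measured compounds shown here, there is no measured pair that isolates such a change at the benzylic position, so there is no direct guide to its size. A step of modest size toward a lower number is expected, most likely within or just beyond the scatter, giving a 1.8-fold lower number from compound 1 to compound 3 (0.26 log units; within the scatter). Compound 3 is accordingly estimated at 3500 nM in this assay, with a range from 900 nM to 14000 nM.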

Compound 3, half-maximal inhibitory concentration: 48100 nM
Compound 3: middle estimate off by 14-fold (1.14 log units), on the low side; the whole stated range lies below it.
By their numbers in this assay, from the lowest: compound 2; then compound 1; then compound 3.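

In this assay, replacing 4-methoxy-3-methylbenzyl with 4-bromobenzyl gives a 7.6-fold higher number from compound 1 to compound 3 (0.88 log units; beyond the scatter), so the group on the saturated chain carbon bound to an amide-type nitrogen clearly matters to the read-out. Compound 1 and compound 2 differed at two places at once and could not assign any part of their gap to this position, whereas this single change, made with the shared core kept intact, shows that 4-bromophenyl does not stand in for 4-methoxy-3-methylphenyl without a loss beyond the scatter. No available evidence bears on the reason for this step, so the finding goes no further than its direction and size.

From the compounds shown here alone, it remains open whether the higher number goes with the departure of the methoxy group, the departure of the methyl group or the arrival of the bromine, as all three changes occur together in this one step. A benzyl group carrying only the methoxy or only the methyl, or one carrying chlorine in place of the bromine, would begin to separate these contributions.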